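A few compounds are considered here, and "the series" means these few. Any claim that something is new, unique, unknown or untested is made for them only; others in the source may bear on it.

Of the compounds shown here, three that share one core have so far been tested in a functional assay on A-375 cells (Homo sapiens) for antiproliferative activity; on this read-out lower numbers stand for stronger inhibition and higher numbers for weaker inhibition. Compound 1 `CCCCO/N=C/c1c(N)ncnc1Oc1ccc2[nH]c(C)cc2c1F` gives 446 nM in this assay. Compound 2 `CO/N=C/c1c(N)ncnc1Oc1ccc2[nH]ccc2c1` gives 783 nM, and compound 3 `CO/N=C/c1c(N)ncnc1Oc1ccc2c(ccn2C)c1` gives 326 nM. Among the measured compounds shown here, the only pair that differs in a single place is compound 2 and compound 3, and that step, a 2.4-fold lower number from compound 2 to compound 3 (0.38 log units; beyond the scatter), comes from a methyl in place of hydrogen on an aromatic nitrogen. On these three numbers compound 1 stands second highest: its nearest neighbour is compound 3, and the gap to it lies within the scatter, as does the gap to compound 2.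

Compound 4 `COCCCO/N=C/c1c(N)ncnc1Oc1ccc2[nH]c(C)cc2c1F` has not yet been measured. It differs from compound 1 in one place: methoxy in place of methyl on a saturated chain carbon, three bonds along the chain from an oxygen on an unsaturated carbon. For the measured compounds named here, no measured step touches this part of the structure; the one step known concerns the aromatic nitrogen, not the saturated chain. With nothing to lean on, the expected step of a 1.1-fold lower number from compound 1 to compound 4 (0.03 log units; within the scatter) is none beyond the scatter. Compound 4 is therefore estimated at 420 nM, within a range from 150 nM to 1200 nM.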

Compound 4, half-maximal inhibitory concentration: 300 nM
Compound 4: middle estimate off by 1.4-fold (0.15 log units), on the high side; measured number inside the range.
By their numbers in this assay, from the lowest: compounds 4, 3, 1 and 2 (each within the scatter of the next, the first and the last beyond it).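

Going from butyl to 3-methoxypropyl places an oxygen in the chain and adds one hydrogen-bond acceptor, and in this assay this gives a 1.5-fold lower number from compound 1 to compound 4 (0.17 log units; within the scatter), so the two compounds cannot be told apart on this read-out. Among the compounds shown here, this is the first measured step on this saturated chain, and it shows that, on the core of compound 1, methoxy can stand in place of methyl here without a change beyond the usual scatter of repeated measurements. Nothing measured on these compounds offers an explanation for this result, and a single pair sets no general rule for the position.

An amine, a carboxylic acid or a longer chain in place of the methoxy could give a very different number, so how much change this end of the chain accepts remains an open question. It is also unknown whether methoxy in place of methyl would give a similarly small step on another core, such as that of compound 2 or compound 3, where the chain is different.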